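Reversing the linker and swapping thiophene for phenyl

A few compounds are considered here, and "the series" means these few. Any claim that something is new, unique, unknown or untested is made for them only; others in the source may bear on it.

Measured so far in a functional assay on MDA-MB-231 cells (Homo sapiens) for cytotoxicity, read by MTT assay, with a stated time of 72 h; on this read-out higher numbers stand for weaker inhibition and lower numbers for stronger inhibition:
compound 1 `COc1ccc(/C=N/NC(=O)Nc2ccc(Oc3ccnc4cc(OCCCN5CCCCC5)c(OC)cc34)c(F)c2)cc1` gives 840 nM;
compound 2 `COc1cc2c(Oc3ccc(NC(=O)N/N=C/c4ccc(O)cc4)cc3F)ccnc2cc1OCCCN1CCCCC1` gives 790 nM;
compound 3 `COc1cc2c(Oc3ccc(NC(=O)N/N=C/c4cccs4)cc3F)ccnc2cc1OCCCN1CCCCC1` gives 1260 nM.

Compound 3 has the highest of the three numbers, but its separation from the others is small: the step of a 1.5-fold higher number from compound 1 to compound 3 (0.18 log units; within the scatter) and the step of a 1.6-fold higher number from compound 2 to compound 3 (0.20 log units; within the scatter) both sit inside the scatter, so the three compounds cannot be ranked against each other on this assay.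

Compound 4 `COc1cc2c(Oc3ccc(/C=N/NC(=O)Nc4ccccc4)cc3F)ccnc2cc1OCCCN1CCCCC1` differs from compound 3 in the group carried on the aromatic carbon of the shared core: a group of 12 heavy atoms (8 carbon, 3 nitrogen, 1 oxygen; one six-membered aromatic ring of carbon only) in place of a group of 11 heavy atoms (6 carbon, 3 nitrogen, 1 oxygen, 1 sulfur; one five-membered aromatic ring with 1 hetero atom), on an aromatic carbon. The change is not just an exchange of the terminal ring; the chain of nitrogens and the carbonyl that connects the core to that ring is also turned around, so that the core now carries the carbon with the double bond to nitrogen.

The measured steps that bear on it, from compound 1 to compound 3 and from compound 2 to compound 3, only exchanged the terminal ring and stayed within the scatter. For the measured compounds named here, no measured pair tests the reversal of the connecting chain. With the terminal ring changes showing no movement, compound 4 is expected to stay near compound 3, with the step of a 1.1-fold lower number from compound 3 to compound 4 (0.02 log units; within the scatter) estimated inside the scatter, but the untested reversal widens the uncertainty. Compound 4 is therefore estimated at 1200 nM, with a range from 350 nM to 4000 nM.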

Compound 4, half-maximal inhibitory concentration: 1200 nM
Compound 4: the middle estimate sits on the measured number at the digits printed, and the stated range covers the measured number.
By their numbers in this assay, from the lowest: compounds 2, 1, 4 and 3 (each within the scatter of the next).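

In this assay, for the compounds shown here, this is the first change at this position, an aromatic carbon meta to a fluoro group, that turns the connecting chain around as well as exchanging the terminal ring, and it gives a 1.1-fold lower number from compound 3 to compound 4 (0.02 log units; within the scatter). For this one pair, then, turning the chain around and replacing the five-membered sulfur-containing ring with a six-membered ring of carbon only produce no shift that can be read on this assay, although the two changes arrive in a single step and could each have no effect or could offset each other. No measurement shown here offers an explanation for this result.

A compound with the turned-around chain that keeps thiophen-2-yl, or one with the original chain that carries an unsubstituted phenyl ring, would be needed to separate the two changes. From the compounds shown here alone, it also remains open whether a carboxylic acid or an amine on the terminal ring of the turned-around series would move the number beyond the scatter.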